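The source may hold more compounds than are shown below. What is called first, only, known or untested is meant among the compounds shown, and "the series" means these compounds.

For the measured compounds named here, compound 1 (`O=C(/C=C/c1ccccc1O)CC(=O)c1ccc(O)c(O)c1`) and compound 2 (`O=C(/C=C/c1cccc(O)c1)CC(=O)c1ccc(O)c(O)c1`) are the two measured members in an ADME assay on PC-12 cells (Rattus norvegicus) for cytotoxicity, read by WST assay, with a stated time of 24 h; a lower number here means that less compound is tolerated, a higher number that more compound is tolerated. Compound 2 gives > 100000 nM, which is a limit of the assay and not a number. Compound 1 gives > 90000 nM, likewise a limit.

Compound 3 (`O=C(/C=C/c1cc(O)ccc1O)CC(=O)c1ccc(O)c(O)c1`) differs from compound 2 by hydroxy in place of hydrogen on an aromatic carbon, ortho to a large group and para to a hydroxy group.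

Going by the values given here, only one measured step bears on this change, a step that the two limits leave unreadable from compound 1 to compound 2. It exchanges 2-hydroxyphenyl for 3-hydroxyphenyl and provides no size to carry over. No step beyond the scatter is therefore expected in this assay, and no direction can be assigned. The expected result is an at least 1.4-fold lower number from compound 2 to compound 3 (0.15 log units; that floor lies within the scatter). Compound 3 is estimated at 70000 nM, with an expected range from 20000 nM to 130000 nM.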

Compound 3, half-maximal cytotoxic concentration in the PC-12 assay: > 100000 nM
Compound 3 was reported as a limit; the forecaster's own chance of this, stated with the estimate: 50%; middle value at least 1.4-fold (0.15 log units) away from the limit.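

In the PC-12 assay compound 1 gives > 90000 nM, which is a limit of the assay and not a number. In the PC-12 assay compound 2 gives > 100000 nM, which is likewise a limit. In the PC-12 assay compound 3 gives > 100000 nM, which is also a limit. No step among these three compounds can be read. The compounds shown leave open where the half-maximal cytotoxic concentration of any of the three lies.

In a physicochemical assay for solubility, using the shake flask method, with a stated time of 12 h (on this read-out lower numbers stand for lower solubility and higher numbers for higher solubility), compound 2 gives 25000 nM. In the physicochemical assay compound 3 gives 47000 nM. In the physicochemical assay the measured step is a 1.9-fold higher number from compound 2 to compound 3 (0.27 log units; within the scatter).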